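The source may report more compounds than this note shows. Statements on the series, on what has been measured and on what is new or still open speak of the compounds shown alone.

Measured compounds and values:

Compound 1, `O=C/C=C/c1ccccc1OCc1cccc(Cl)c1`, gives 5900 nM in a functional assay on cells (Neutrophil, Rattus norvegicus, strain Sprague-Dawley) for inhibition; a higher number here means a weaker inhibitor, a lower number a stronger inhibitor.
Compound 2, `O=C/C=C/c1ccccc1OCc1ccc(Cl)c(Cl)c1`, gives 4300 nM in this assay.
Compound 3, `COc1ccc(OCc2ccccc2)c(/C=C/C=O)c1`, gives 2600 nM in this assay.

The three measured compounds share a cinnamaldehyde-bearing core carrying a benzyl ether, and they differ in what sits on the ether-linked ring and on the core itself. Compound 1 and compound 2 differ in one place, (chloro in place of hydrogen on an aromatic carbon), and this change gave a 1.4-fold lower number from compound 1 to compound 2 (0.14 log units; within the scatter), a step that stays within the usual scatter. Compound 3 has a different core from compound 1; the difference between the two cores is not broken down here. Compound 3 and compound 2 lie within the scatter of each other, while compound 3 stands beyond the scatter from compound 1.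

Compound 4, `COc1ccc(OCc2cccc(Cl)c2)c(/C=C/C=O)c1`, is not yet measured. It differs from compound 3 by chloro in place of hydrogen on an aromatic carbon. Among the measured compounds shown here, this is the same kind of change as the one from compound 1 to compound 2, but not the same: in compound 2 the chloro sits ortho to a chloro group and para to a large group, whereas in compound 4 it sits meta to a large group, and compound 3 carries a methoxy that compound 1 lacks.

For the measured compounds named here, the expectation for compound 4 rests on the single measured step of this kind, because a 1.4-fold lower number from compound 1 to compound 2 (0.14 log units; within the scatter) was small and within the scatter. Compound 4 is therefore expected to show a step of a 1.3-fold lower number from compound 3 to compound 4 (0.11 log units; within the scatter), a modest change at most. Compound 4 is estimated at 2000 nM, with a range from 900 nM to 4500 nM.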

Compound 4, half-maximal inhibitory concentration: 4200 nM
For compound 4 the middle estimate is 2.1-fold (0.32 log units) below the measured one; low and high end bracket the measured number.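

In this assay, chloro in place of hydrogen on the core that carries the methoxy gave a 1.6-fold higher number from compound 3 to compound 4 (0.21 log units; within the scatter), and methoxy in place of hydrogen on the core of compound 1 gave a 1.4-fold lower number from compound 1 to compound 4 (0.15 log units; within the scatter), so neither step can be told apart from the scatter. Set beside the earlier chloro step, the new one does not differ from it by more than two such steps can differ by chance: the same change on two cores in this assay, a 1.4-fold lower number (0.14 log units; within the scatter) from compound 1 to compound 2 and a 1.6-fold higher number (0.21 log units; within the scatter) from compound 3 to compound 4, 2.2-fold (0.35 log units) apart, within the scatter of two such steps. This shows that on both cores the chloro step stays small, and that these two readings are compatible with it carrying over from one core to the other, but it does not show that the change is truly without effect or that the two steps are the same, as each is too small to give it a direction and the chloro does not sit in the same place in the two pairs.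

The compounds shown leave open whether groups other than chloro on the benzyl ring, such as an amine or a carboxylic acid, would give a step that rises clearly above the scatter. They also leave open how the aldehyde chain contributes, for instance whether a longer chain or a carboxylic acid in place of the aldehyde would keep the inhibition seen here.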